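Two close values and one unmeasured compound

The source may hold more compounds than are shown below. What is called first, only, known or untested is meant among the compounds shown, and "the series" means these compounds.

Measured in a functional assay for inhibition, read by fluorescence and spectrophotometry, with a stated time of 30 h; on this read-out lower numbers stand for stronger inhibition and higher numbers for weaker inhibition:
- compound 1 `COc1ccc(-c2cc(=O)c3ccc(OCCCN4CCC(C)CC4)cc3o2)cc1`: 42600 nM
- compound 2 `COc1ccc(-c2cc(=O)c3ccc(OCCCCCCN4CCC(CCO)CC4)cc3o2)cc1`: 50400 nM

In this assay, compound 2 stands at 50400 nM and compound 1 at 42600 nM. These two values lie within the usual scatter of each other, so neither compound stands apart.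

Compound 3 `COc1ccc(-c2cc(=O)c3ccc(OCCCCCCCN4CCC(C)CC4)cc3o2)cc1` has not yet been measured. Its difference from compound 2 is (4-methylpiperidin-1-yl)methyl in place of 4-(2-hydroxyethyl)piperidin-1-yl on a saturated chain carbon, six bonds along the chain from an oxygen on an aromatic ring. In words, (4-methylpiperidin-1-yl)methyl stands in place of 4-(2-hydroxyethyl)piperidin-1-yl on a saturated chain carbon, six bonds along the chain from an oxygen on an aromatic ring.

For the measured compounds named here, no measured pair shows this change alone, so the expectation rests on those two close values. The expected move is a 1.3-fold lower number from compound 2 to compound 3 (0.10 log units; within the scatter), which is estimated to stay within the scatter. In this assay, the estimated value for compound 3 is 40000 nM, with an expected range of 15000 nM to 90000 nM.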

Compound 3, half-maximal inhibitory concentration: 61600 nM
Compound 3: middle estimate off by 1.5-fold (0.19 log units), on the low side; measured number inside the range.
By their numbers in this assay, from the lowest: compounds 1, 2 and 3 (each within the scatter of the next).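

In this assay the exchange of 4-(2-hydroxyethyl)piperidin-1-yl for (4-methylpiperidin-1-yl)methyl, on a saturated chain carbon six bonds along the chain from an oxygen on an aromatic ring, gives a 1.2-fold higher number from compound 2 to compound 3 (0.09 log units; within the scatter) and so stays within the scatter, even though the hydrogen-bond donor of the leaving group is gone. Likewise, 4-(4-methylpiperidin-1-yl)butyl in place of 4-methylpiperidin-1-yl, on a saturated chain carbon three bonds along the chain from an oxygen on an aromatic ring, gives a 1.4-fold higher number from compound 1 to compound 3 (0.16 log units; within the scatter) and also stays within the scatter. Nothing available accounts for either step.

On these data alone, all three compounds end in a substituted piperidine, so it remains open whether a morpholine or a carboxylic acid at the chain end would give a number beyond the scatter.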